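The source may hold more compounds than are shown below. What is called first, only, known or untested is meant among the compounds shown, and "the series" means these compounds.

In an assay on SW48 cells for inhibition of Tryptophan 2,3-dioxygenase (Homo sapiens), read by fluorescence, with a stated time of 30 min (on this read-out lower numbers stand for an effect already at smaller amounts and higher numbers for an effect only at larger amounts of compound), three compounds have been measured so far.

Compound 1, `Nc1oncc1-c1ccccc1`: 85 nM.
Compound 2, `CNC(=O)c1oncc1-c1ccccc1`: > 25000 nM, which is a limit of the assay and not a number.
Compound 3, `Nc1oncc1-c1ccc(Cl)cc1`: 950 nM.

Compound 3 holds the highest of the two numbers that were read; its nearest neighbour is compound 1, and the change is an 11-fold higher number from compound 1 to compound 3 (1.05 log units; beyond the scatter). The other step, an at least 290-fold higher number from compound 1 to compound 2 (2.46 log units; beyond the scatter), concerns the group on the shared core rather than the phenyl ring and does not bear on the present question.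

Compound 4 is `Nc1oncc1-c1ccc(F)cc1`. It differs from compound 3 by fluoro in place of chloro on an aromatic carbon. Among the compounds with values here, no measured pair shows this exchange directly. What is known is that adding chloro at that position gave an 11-fold higher number from compound 1 to compound 3 (1.05 log units; beyond the scatter), so the unsubstituted compound 1 and the chloro compound 3 bracket the possibilities. Fluoro is the smaller halogen and is expected to sit between them, nearer the unsubstituted end. For compound 4 the expected step is therefore a 3.8-fold lower number from compound 3 to compound 4 (0.58 log units; beyond the scatter), a lower number in this assay. Compound 4 is thus estimated at 250 nM, with a range from 100 nM to 700 nM.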

Compound 4, half-maximal effective concentration: 210 nM
Beside the measured number, compound 4's estimate is 1.2-fold (0.08 log units) above it; measured number inside the range.
By their numbers in this assay, from the lowest: compound 1; then compound 4; then compound 3. At a limit, above all of these: compound 2.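

Compound 4 gives this position its first direct exchange of one halogen for another: in this assay, fluoro in place of chloro brings a 4.5-fold lower number from compound 3 to compound 4 (0.66 log units; beyond the scatter) and so shows that the outcome at this aromatic carbon depends on which halogen sits there, not only on whether one does. Fluoro in place of hydrogen does not leave the number where it was, however, since a 2.5-fold higher number from compound 1 to compound 4 (0.39 log units; beyond the scatter) remains beyond the scatter, and fluoro therefore does not restore the value of the unsubstituted compound 1. Across compound 1, compound 4 and compound 3, the numbers now rise in the order hydrogen, fluoro, chloro; none of these compounds goes against that order, although it rests on only three groups at one position.

From the compounds shown here alone, whether the order extends to bromo, and where a methyl or methoxy group at the same carbon would fall, remains open, as does whether fluoro and chloro would behave alike elsewhere on the ring. Nothing in the data shown bears on why fluoro and chloro differ at this position.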